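The compounds below may be only part of what the source reports. "The series", "measured", "known", "first", "only" and "open" are said of these compounds alone.

Compound 1 `COc1cc(C(=O)N/N=C/c2ccc(F)c(F)c2)cc(OC)c1OC`: 33.1%
Compound 2 `COc1cc(C2=NN(C(C)=O)C(c3cccc(OC)c3OC)O2)cc(OC)c1OC`: 3.8%
Compound 3 `COc1cc(C2=NN(C(C)=O)C(c3cc(OC)c(OC)c(OC)c3)O2)cc(OC)c1OC`: -1.8%

These three compounds were tested in a functional assay on BGC-823 cells (Homo sapiens) for antiproliferative activity, read by MTT assay, tested at 1 uM; a higher number here means a stronger effect of the compound at the concentration tested, a lower number a weaker effect. Compound 2 stands second highest of the three numbers. Its nearest neighbour is compound 3, whose number lies lower by an amount within the usual scatter, so the two cannot be told apart. Compound 1, built differently from the shared core of compounds 2 and 3, lies far higher, beyond the scatter.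

Compound 4 `COc1cc(C2=NN(C(C)=O)C(c3ccccc3C(F)(F)F)O2)cc(OC)c1OC` has not yet been measured. It differs from compound 2 in one place: 2-(trifluoromethyl)phenyl in place of 2,3-dimethoxyphenyl on a saturated ring carbon. Going by the values given here, no step between measured compounds carries this kind of change, so its effect must be judged indirectly. Among the compounds with values here, compounds 2 and 3 share the same core and differ only in the group on that saturated ring carbon, yet both give numbers close to zero in this assay; this hints that the group there has little room to move the read-out, though only two examples support the idea. The step from compound 2 to compound 4 is therefore expected to be small, none beyond the scatter, a number 2.2 percentage points higher from compound 2 to compound 4 (within the scatter). For compound 4 the estimated value in this assay is 6%, with a range from -8% to 22%.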

Compound 4, a percentage reported as inhibition, at one concentration (the size of the read-out at that concentration, not a potency): 31.8%
Beside the measured number, compound 4's estimate is 25.8 percentage points below it, outside the stated range (above it).
By their numbers in this assay, from the lowest: compounds 3 and 2 (each within the scatter of the next); then compounds 4 and 1 (each within the scatter of the next).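

In this assay, the group on the saturated ring carbon turns out to matter: a number 28 percentage points higher from compound 2 to compound 4 (beyond the scatter), the first step at this position shown to lie beyond the scatter. Compound 2 gives 3.8% and compound 3 gives -1.8%, two numbers that cannot be told apart, so those methoxy-bearing groups alone gave no sign that this position could change the read-out so clearly, while 2-(trifluoromethyl)phenyl shows that it can, with the same count of 10 heavy atoms entering as leaving. Nothing measured here explains the rise.

The swap changes two things at once, taking away both methoxy groups and bringing in a trifluoromethyl group, so these compounds cannot show which of the two matters; a plain phenyl ring, or a phenyl ring carrying a single methoxy group or a single chlorine atom, would help to separate them. Going by these compounds, each number is also a read-out at one concentration, so how strong the effect of compound 4 is at other concentrations, and whether the stronger effect holds in other cells, stays open.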